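Same change repeated at a second position in a small series

A few compounds are considered here, and "the series" means these few. Any claim that something is new, unique, unknown or untested is made for them only; others in the source may bear on it.

Three analogues share one core. Compound 1 `CN(C(=O)NC(=O)c1ccc(F)c(F)c1)c1nc(C(F)(F)F)c(C(=O)N/N=C/c2ccccc2C(F)(F)F)s1` in a functional assay on HepG2 cells (Homo sapiens) for inhibition, read by MTT assay, with a stated time of 72 h (a lower number here means a stronger inhibitor, a higher number a weaker inhibitor), gives 10.4 ug/mL. Compound 2 `CN(C(=O)NC(=O)c1ccc(F)c(F)c1)c1nc(C(F)(F)F)c(C(=O)N/N=C/c2cccc(C(F)(F)F)c2)s1` gives 5.6 ug/mL, and compound 3 `CN(C(=O)NC(=O)c1ccccc1F)c1nc(C(F)(F)F)c(C(=O)N/N=C/c2ccccc2C(F)(F)F)s1` gives 5.39 ug/mL. Compounds 1 and 2 differ by 3-(trifluoromethyl)phenyl in place of 2-(trifluoromethyl)phenyl on a carbon with a double bond to nitrogen, and the step is a 1.9-fold lower number from compound 1 to compound 2 (0.27 log units; within the scatter). Compounds 1 and 3 differ in the core by 2-fluorophenyl in place of 3,4-difluorophenyl on a carbonyl carbon, with a step of a 1.9-fold lower number from compound 1 to compound 3 (0.29 log units; within the scatter). Compound 4 `CN(C(=O)NC(=O)c1ccccc1F)c1nc(C(F)(F)F)c(C(=O)N/N=C/c2cccc(C(F)(F)F)c2)s1` is not yet measured in this assay; it differs from compound 3 by 3-(trifluoromethyl)phenyl in place of 2-(trifluoromethyl)phenyl on a carbon with a double bond to nitrogen, the same change, at the same place, as from compound 1 to compound 2, and this change occurs twice among the compounds shown. Going by the values given here, for compound 4 the expected step is a 1.5-fold lower number from compound 3 to compound 4 (0.19 log units; within the scatter), set beside the measured step of a 1.9-fold lower number from compound 1 to compound 2 (0.27 log units; within the scatter), because a 1.9-fold lower number from compound 1 to compound 2 (0.27 log units; within the scatter) is the only precedent for this change and it sits within the scatter. Compound 4 is estimated at 3.5 ug/mL, with a likely range from 1.8 ug/mL to 7 ug/mL.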

Compound 4, half-maximal inhibitory concentration: 20.3 ug/mL
For compound 4 the middle estimate is 5.8-fold (0.76 log units) below the measured one; measured number above the stated range.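

In this assay, the change to 3-(trifluoromethyl)phenyl gives a 3.8-fold higher number from compound 3 to compound 4 (0.58 log units; beyond the scatter), so its earlier direction does not carry over to the core bearing 2-fluorophenyl: the same change on two cores in this assay, a 1.9-fold lower number (0.27 log units; within the scatter) from compound 1 to compound 2 and a 3.8-fold higher number (0.58 log units; beyond the scatter) from compound 3 to compound 4, 7.0-fold (0.84 log units) apart, beyond the scatter of two such steps
The change to 2-fluorophenyl on the carbonyl carbon gives a 3.6-fold higher number from compound 2 to compound 4 (0.56 log units; beyond the scatter), and it too depends on the group at the other position: the same change on two cores in this assay, a 1.9-fold lower number (0.29 log units; within the scatter) from compound 1 to compound 3 and a 3.6-fold higher number (0.56 log units; beyond the scatter) from compound 2 to compound 4, 7.0-fold (0.84 log units) apart, beyond the scatter of two such steps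
Within these four compounds the two changes therefore do not act independently, but this does not show why, and a single pair per core sets no rule for any other core.

As far as these compounds go, it remains open whether this dependence persists with a nitrile or a methoxy group in place of trifluoromethyl on that ring. From the compounds shown here alone, it is also open whether it persists with a chlorine in place of fluorine on the phenyl ring at the carbonyl carbon.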